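Benzylation of a thiosemicarbazone pair on MCF7 cells

The source may report more compounds than this note shows. Statements on the series, on what has been measured and on what is new or still open speak of the compounds shown alone.

Measured compounds:
compound 1 `Cc1cccc(NC2=C/C(=N/NC(N)=S)C(=O)N=C2Nc2cccc(C)c2)c1` 150 nM
compound 2 `COc1ccc(NC2=C/C(=N/NC(N)=S)C(=O)N=C2Nc2ccc(OC)cc2)cc1` 10400 nM

In a functional assay on MCF7 cells (Homo sapiens) for antiproliferative activity, read by MTT assay, with a stated time of 72 h (a lower number here means a stronger inhibitor, a higher number a weaker inhibitor), compound 1 gives 150 nM and holds the lowest number of the two, with compound 2 at 10400 nM, a gap beyond the scatter. Compound 3 `Cc1cccc(NC2=C/C(=N/N=C(\N)SCc3ccccc3)C(=O)N=C2Nc2cccc(C)c2)c1` differs from compound 1 by a group of 11 heavy atoms (8 carbon, 2 nitrogen, 1 sulfur; one six-membered aromatic ring of carbon only) in place of a group of 4 heavy atoms (1 carbon, 2 nitrogen, 1 sulfur; no ring), on a double-bonded nitrogen. For the measured compounds named here, no measured pair shows this step, so its size is unknown; a shift in either direction of moderate size, or none beyond the scatter, seems possible. Compound 3 is expected to give 400 nM in this assay, between 80 nM and 2500 nM, a step of a 2.7-fold higher number from compound 1 to compound 3 (0.43 log units; beyond the scatter) from compound 1.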

Compound 3, half-maximal inhibitory concentration: 9340 nM
Compound 3: the middle estimate sits 23-fold (1.37 log units) below what was measured, outside the stated range (above it).
By their numbers in this assay, from the lowest: compound 1; then compounds 3 and 2 (each within the scatter of the next).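

In this assay, this double-bonded nitrogen proves a place where the outcome depends strongly on what is attached: the group of 11 heavy atoms, with its six-membered aromatic ring of carbon only, in place of the group of 4 heavy atoms gives a 62-fold higher number from compound 1 to compound 3 (1.79 log units; beyond the scatter). Much of the activity of compound 1 is therefore lost with this single change. Nothing at hand gives a reason for the loss. From the compounds shown here alone, whether a methyl group on the sulfur would retain more activity remains open, as does the effect of the same change on compound 2.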